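Ethoxy for diethylamino on the shared core

A few compounds are considered here, and "the series" means these few. Any claim that something is new, unique, unknown or untested is made for them only; others in the source may bear on it.

Measured compounds:
compound 1, `CCN(CC)c1cc2nc(-c3ccccc3)nn(-c3ccccc3)c-2cc1=O`: 3110 nM
compound 2, `O=c1cc2n(-c3ccccc3)nc(-c3ccccc3)nc-2cc1N1CCCC1`: 2460 nM

In a functional assay on DU-145 cells (Homo sapiens) for cytotoxicity, read by MTT assay, with a stated time of 72 h (on this read-out lower numbers stand for stronger inhibition and higher numbers for weaker inhibition), compound 1 gives 3110 nM, the highest of the two numbers in hand; compound 2 gives 2460 nM, and the step of a 1.3-fold lower number from compound 1 to compound 2 (0.10 log units; within the scatter) lies within the scatter, so the two values are not distinguishable. Compound 3, `CCOc1cc2nc(-c3ccccc3)nn(-c3ccccc3)c-2cc1=O`, has not yet been measured in this assay. It differs from compound 1 in one place: ethoxy in place of diethylamino on an aromatic carbon. For the measured compounds named here, no measured step exchanges a nitrogen-linked group for an oxygen-linked group on this position of the shared core; the only step known, from compound 1 to compound 2, swaps one amine for another and leaves the number where it was. There is therefore no basis for expecting a step beyond the scatter in this assay. The step from compound 1 to compound 3 is estimated at a 1.2-fold higher number from compound 1 to compound 3 (0.06 log units; within the scatter), in either direction within the scatter. Compound 3 is thus expected to give 3600 nM, with a range of 1500 nM to 9000 nM.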

Compound 3, half-maximal inhibitory concentration: > 5000 nM
Compound 3: no number, only a limit; the forecaster's own chance of this, stated with the estimate: 10%; middle value at least 1.3-fold (0.14 log units) away from the limit.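

In this assay compound 3 gives no number, only a limit, so its result marks a floor and not a position: the limit of > 5000 nM in this assay, at which 1 of the 3 values shown sits. Read against the two amines, ethoxy in place of diethylamino gives an at least 1.6-fold higher number from compound 1 to compound 3 (0.20 log units; that floor lies within the scatter), and ethoxy in place of pyrrolidin-1-yl gives an at least 2.0-fold higher number from compound 2 to compound 3 (0.30 log units; that floor lies within the scatter); both floors lie within the scatter, so neither step is shown to exceed it, though either may be larger. The earlier pair held only nitrogen-linked groups at this place and could not be told apart, whereas compound 3 brings the first oxygen-linked group there and the first result that ends at a limit, which raises the possibility that the oxygen-linked group does not match the amines without establishing it.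

On these data alone, how far compound 3 lies beyond its limit remains open, as does whether the linking oxygen or the smaller count of heavy atoms matters more. A longer ether such as butoxy, set against a small amine such as ethylamino at the same place, could separate these two changes.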